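The source may report more compounds than this note shows. Statements on the series, on what has been measured and on what is new or still open speak of the compounds shown alone.

Compound 3 `CCCCc1ccc(CNS(=O)(=O)c2ccc(C)cc2)c(=O)n1Cc1ccc(-c2ccccc2-c2nn[nH]n2)cc1` gives 9 nM in a functional assay (aorta) for antagonist activity, with Oryctolagus cuniculus as the target; a lower number here means a stronger inhibitor, a higher number a weaker inhibitor. Among the three compounds measured so far it gives the highest number. Compound 1 `CCCCc1ccc(CNCc2ccccc2)c(=O)n1Cc1ccc(-c2ccccc2-c2nn[nH]n2)cc1` gives 1 nM in this assay, and compound 2 `CCCCc1ccc(CN(Cc2ccccc2)C(C)=O)c(=O)n1Cc1ccc(-c2ccccc2-c2nn[nH]n2)cc1` gives 1 nM. The step of a 9.0-fold higher number from compound 1 to compound 3 (0.95 log units; beyond the scatter) and the step of a 9.0-fold higher number from compound 2 to compound 3 (0.95 log units; beyond the scatter) both lie beyond the scatter, whereas the step of no change at the digits printed from compound 1 to compound 2 (within the scatter) lies within it.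

Compound 4 `CCCCc1ccc(CN(Cc2ccccc2)S(=O)(=O)c2ccc(C)cc2)c(=O)n1Cc1ccc(-c2ccccc2-c2nn[nH]n2)cc1` differs from compound 3 in one place: benzyl in place of hydrogen on a sulfonamide nitrogen. Within the data shown here, two measured steps bear on this change. In the step of no change at the digits printed from compound 1 to compound 2 (within the scatter), a nitrogen that already carries a benzyl group receives a second substituent, and the number does not move. In the step of a 9.0-fold higher number from compound 1 to compound 3 (0.95 log units; beyond the scatter), the benzyl group is exchanged for the (4-methylphenyl)sulfonyl group, and the number rises. Compound 4 carries both the benzyl and the (4-methylphenyl)sulfonyl group, much as compound 2 carries both the benzyl and the acetyl group. On this basis compound 4 is expected to land between compound 3 and compound 2, with a modest lowering of the number, as the step of a 2.3-fold lower number from compound 3 to compound 4 (0.35 log units; beyond the scatter) expresses. Compound 4 is therefore estimated at 4 nM, within a range from 1.5 nM to 12 nM.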

Compound 4, half-maximal inhibitory concentration: 60 nM
Compound 4: the middle estimate sits 15-fold (1.18 log units) below what was measured; measured number outside the range, above it.
By their numbers in this assay, from the lowest: compounds 1 and 2 (each within the scatter of the next); then compound 3; then compound 4.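

Among these compounds, on the sulfonamide nitrogen, benzyl in place of hydrogen gives a 6.7-fold higher number from compound 3 to compound 4 (0.82 log units; beyond the scatter) in this assay and so moves the number upward, something the earlier compounds did not show, since the only second substituent they placed on a benzyl-bearing nitrogen, acetyl, gave no change at the digits printed from compound 1 to compound 2 (within the scatter) with no shift. The group that enters this nitrogen therefore decides the outcome: (4-methylphenyl)sulfonyl in place of hydrogen gives a 60-fold higher number from compound 1 to compound 4 (1.78 log units; beyond the scatter) on the amine nitrogen, and the same group in place of acetyl gives a 60-fold higher number from compound 2 to compound 4 (1.78 log units; beyond the scatter) at that position. Benzyl and (4-methylphenyl)sulfonyl together on one nitrogen thus give the highest number of the four compounds, whereas benzyl and acetyl together leave the number where compound 1 has it.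

From the compounds shown here alone, whether a methyl or ethyl group on the sulfonamide nitrogen would raise the number as benzyl does, and whether a methanesulfonyl group in place of (4-methylphenyl)sulfonyl would give the same rise, stays open. Nothing at hand accounts for the different outcomes of acetyl and (4-methylphenyl)sulfonyl on this nitrogen.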